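The compounds below may be only part of what the source reports. "The series", "measured", "known", "first", "only" and "open" are said of these compounds alone.

Of the compounds shown here, three have been measured in a functional assay on the whole organism (stomach, strain beagle) for inhibition, with Canis familiaris (Canis lupus familiaris) as the target, with a stated time of 2 h, at a dose of 16 mg/kg; a lower number here means a weaker effect, a higher number a stronger effect of the compound at the dose given. Compound 3 `N=C(CS)NC(c1ccccc1)c1ccccc1` stands highest of the three numbers: in this assay compound 3 gives 82%. The nearest of the other two is compound 2 `N=C(CS)NCC12CCCC(CCC1)C2`, which in this assay gives 23%, a number well beyond the usual scatter below compound 3. Furthest from compound 3 lies compound 1 `N=C(CSCc1ccccc1)NC[C@@H]1C[C@H]2CC[C@H]1C2`, which in this assay gives 19%, again a separation beyond the scatter. None of these three compounds differs from another in a single place, so no isolated structural step can be read from the measured set.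

Compound 4 `N=C(CS)NC(c1ccccc1)c1ccc(Cl)cc1` is the next compound to be measured in this assay. It differs from compound 3 in one place: chloro in place of hydrogen on an aromatic carbon. For the measured compounds named here, there is no measured pair in the set that shows what such a change does in this assay, so the expectation for compound 4 rests on compound 3 alone, whose value 82% already lies near the top of the scale. The step from compound 3 to compound 4 is expected to be small, a number 4 percentage points lower from compound 3 to compound 4 (within the scatter), most likely within the scatter in either direction. For compound 4 the estimated value in this assay is 78%, with a range from 55% to 92%.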

Compound 4, a percentage reported as inhibition, in the whole organism at one dose (the size of the read-out at that dose, not a potency): 87%
For compound 4 the middle estimate is 9 percentage points below the measured one; the measured number falls inside the stated range.
By their numbers in this assay, from the lowest: compounds 1 and 2 (each within the scatter of the next); then compounds 3 and 4 (each within the scatter of the next).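

In this assay, for the compounds shown here, putting chloro in place of hydrogen on an aromatic carbon, para to a large group, gives a number 5 percentage points higher from compound 3 to compound 4 (within the scatter), the first step in this set that isolates a change at a single place. It shows that, in this pair and at this dose, the six-membered aromatic ring of compound 3 accepts a chloro at this position with no change beyond the usual scatter, so the whole-organism effect is retained but cannot be said to improve. The data at hand offer no measured explanation of why the effect is retained at this position.

The compounds shown leave open whether a methoxy group, an amine or a carboxylic acid at this same place would keep the effect as chloro does, and whether a second chloro on the other aromatic ring would do the same. They also leave open what a single change elsewhere in the shared core would do, such as a methyl group on the sulfur of compound 3.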